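This account rests on a few compounds, and the source may have more. Where it says the series, first, only, none or still open, it means among the compounds named here.

Compound 1 `CCCCCCCCCc1ccc(NC(=O)Nc2c(C(C)C)cccc2C(C)C)cc1` gives 9 nM in an assay on isolated protein for inhibition of acyl-CoA:cholesterol acyltransferase (Oryctolagus cuniculus); on this read-out higher numbers stand for weaker inhibition and lower numbers for stronger inhibition.
Compound 2 `CCCCc1ccc(NC(=O)Nc2c(C(C)C)cccc2C(C)C)cc1` gives 29 nM in this assay.
Compound 3 `CCCCCCCc1ccc(NC(=O)Nc2c(C(C)C)cccc2C(C)C)cc1` gives 19 nM in this assay.

These three compounds share one core and differ only in the chain carried on one ring. Compound 3 stands second highest of the three numbers; its nearest neighbour is compound 2, with a 1.5-fold lower number from compound 2 to compound 3 (0.18 log units; within the scatter), and its furthest is compound 1, with a 2.1-fold higher number from compound 1 to compound 3 (0.32 log units; beyond the scatter).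

Compound 4 `CCCCCCCCCCCc1ccc(NC(=O)Nc2c(C(C)C)cccc2C(C)C)cc1` has not been measured. It differs from compound 3 by butyl in place of hydrogen on a saturated chain carbon, seven bonds along the chain from an aromatic carbon.

Among the measured compounds shown here, two measured steps bear on this change. The step of a 2.1-fold higher number from compound 1 to compound 3 (0.32 log units; beyond the scatter) shows that removing ethyl at that same place gave a modest rise in number, so adding carbon there may give a modest fall. The step of a 3.2-fold higher number from compound 1 to compound 2 (0.51 log units; beyond the scatter) points the same way. The step of a 1.5-fold lower number from compound 2 to compound 3 (0.18 log units; within the scatter) is smaller and within the scatter. For the measured compounds named here, a modest fall in this assay is therefore expected, roughly a 2.4-fold lower number from compound 3 to compound 4 (0.38 log units; beyond the scatter), though no measured compound shows whether a chain beyond that of compound 1 keeps helping. Compound 4 is estimated at 8 nM, in a range from 3 nM to 25 nM.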

Compound 4, half-maximal inhibitory concentration: 9 nM
Compound 4: the middle estimate sits 1.1-fold (0.05 log units) below what was measured; the range from low to high includes it.
By their numbers in this assay, from the lowest: compounds 1 and 4 (each within the scatter of the next); then compounds 3 and 2 (each within the scatter of the next).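

Compound 4 shows that the gain from lengthening the chain extends to this longer chain: adding butyl at this place gives a step of modest size (a 2.1-fold lower number from compound 3 to compound 4 (0.32 log units; beyond the scatter)) in this assay, and adding heptyl to the shorter chain gives a similar step in size (a 3.2-fold lower number from compound 2 to compound 4 (0.51 log units; beyond the scatter)). Among the compounds shown here, what the earlier compounds could not show is what happens beyond the chain of compound 1, and adding ethyl at the place nine bonds along the chain from an aromatic carbon brings no gain (no change at the digits printed from compound 1 to compound 4 (within the scatter)), so the fall in number does not carry on past compound 1 in this pair. No separate measurement here speaks to what lies behind this levelling.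

On these data alone, whether a still longer chain would hold this level or lose strength remains open. So does whether an amine or a carboxylic acid at the far end of the chain would be tolerated.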